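This account rests on a few compounds, and the source may have more. Where it says the series, first, only, none or still open, it means among the compounds named here.

Compound 1 `NC(=S)N1N=C(c2ccc(Br)cc2)CC1c1ccc2ccccc2c1` measured at 230 nM
Compound 2 `c1ccc(C2=NN(c3ccccc3)C(c3ccc4ccccc4c3)C2)cc1` measured at 220 nM

In a functional assay on A549 cells (Homo sapiens) for antiproliferative activity, read by MTT assay, with a stated time of 24 h (on this read-out lower numbers stand for stronger inhibition of growth and higher numbers for weaker inhibition of growth), compound 1 stands at 230 nM and compound 2 at 220 nM in the same test. These two numbers lie within the usual scatter of each other, so they do not rank the compounds.

Compound 3 `NC(=S)N1N=C(c2ccc(Cl)c(Cl)c2)CC1c1ccc2ccccc2c1` has not been measured yet. It keeps the core of compound 1 and carries 3,4-dichlorophenyl in place of 4-bromophenyl on a carbon with a double bond to nitrogen. Among the measured compounds shown here, the two measured compounds differ in more than one place, so no measured step shows what this swap does. With no evidence pointing either way, no step beyond the scatter is expected in this assay. The estimated change is small (a 1.2-fold lower number from compound 1 to compound 3 (0.06 log units; within the scatter)). For compound 3 the expected value is 200 nM (range 80 nM to 500 nM).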

Compound 3, concentration for 50% growth inhibition: 310 nM
Beside the measured number, compound 3's estimate is 1.6-fold (0.19 log units) below it, and the stated range covers the measured number.
By their numbers in this assay, from the lowest: compounds 2, 1 and 3 (each within the scatter of the next).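

In this assay, putting 3,4-dichlorophenyl in place of 4-bromophenyl on a carbon with a double bond to nitrogen gives a 1.3-fold higher number from compound 1 to compound 3 (0.13 log units; within the scatter) on the shared core. Among the compounds shown here, this is the first direct reading at this position: two chlorine atoms on the phenyl ring, instead of one bromine, produce no change that can be told apart from ordinary test-to-test variation. No measurement available here bears on why these two groups read alike.

As far as these compounds go, both groups are halogen-bearing phenyl rings, so it remains open whether this position would accept something of a different kind, such as an amine, a carboxylic acid or a longer chain, in place of the ring. From the compounds shown here alone, it is also open how a methoxy group on that phenyl ring would read.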